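Fluoro for bromo on the amide-bound phenyl ring

The compounds below may be only part of what the source reports. "The series", "measured", "known", "first", "only" and "open" are said of these compounds alone.

Compound 2 `O=C(CN1CCN(c2nnc(Cc3ccncc3)c3ccccc23)CC1)Nc1cccc(Br)c1` gives the lower of the two numbers in a functional assay on HT-29 cells (Homo sapiens) for cytotoxicity, read by MTT assay, with a stated time of 72 h (a lower number here means a stronger inhibitor, a higher number a weaker inhibitor), at 1350 nM, while compound 1 `COc1ccc(NC(=O)CN2CCN(c3nnc(Cc4ccncc4)c4ccccc34)CC2)cc1OC` gives 40100 nM. Compound 3 `O=C(CN1CCN(c2nnc(Cc3ccncc3)c3ccccc23)CC1)Nc1cccc(F)c1` differs from compound 2 by fluoro in place of bromo on an aromatic carbon. Going by the values given here, the single measured step, a 30-fold lower number from compound 1 to compound 2 (1.47 log units; beyond the scatter), altered the same aryl group and shows that this part of the molecule moves the number strongly, yet it does not directly compare two halogens. A moderate weakening is therefore expected, a 3.0-fold higher number from compound 2 to compound 3 (0.47 log units; beyond the scatter). Compound 3 is estimated at 4000 nM, within 1000 nM to 16000 nM.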

Compound 3, half-maximal inhibitory concentration: 6130 nM
Compound 3: the middle estimate sits 1.5-fold (0.19 log units) below what was measured, and the stated range covers the measured number.
By their numbers in this assay, from the lowest: compound 2; then compound 3; then compound 1.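

In this assay, the identity of the halogen on this aromatic carbon matters by itself, with a 4.5-fold higher number from compound 2 to compound 3 (0.66 log units; beyond the scatter). The 3-fluorophenyl group still keeps part of the gain over the 3,4-dimethoxyphenyl group, with a 6.5-fold lower number from compound 1 to compound 3 (0.82 log units; beyond the scatter). No measurement available here accounts for the difference between bromo and fluoro. On these data alone, whether chloro, iodo or trifluoromethyl on the same aromatic carbon would give a number lower than that of compound 2 remains open. So does what an amine there would do.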